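Removing a Methoxy Group from a Coumarin-Linked Dienone

The source may report more compounds than this note shows. Statements on the series, on what has been measured and on what is new or still open speak of the compounds shown alone.

Of the compounds shown here, three have been measured in a functional assay on COLO 205 cells (Homo sapiens) for inhibition, read by sulforhodamine B assay, with a stated time of 48 h, tested at 50 uM; on this read-out higher numbers stand for more inhibition of growth at the one concentration tested and lower numbers for less inhibition of growth. Compound 1 `COc1ccccc1/C=C/C(=O)/C=C/c1ccc(OCc2cn(CCCCCOc3cc(=O)oc4ccccc34)nn2)c(OC)c1` gives 30%, compound 2 `COc1cc(/C=C/C(=O)/C=C/c2ccccc2)ccc1OCc1cn(CCCCCOc2cc(=O)oc3ccccc23)nn1` gives 22%, and compound 3 `COc1ccc(/C=C/C(=O)/C=C/c2ccc(OCc3cn(CCCOc4cc(=O)oc5ccccc45)nn3)c(OC)c2)cc1` gives 53%. The change from compound 1 to compound 2 is hydrogen in place of methoxy on an aromatic carbon, and the step was a number 8 percentage points lower from compound 1 to compound 2 (within the scatter). The difference between the core of compound 1 and the core of compound 3 is not broken down here. Compound 4 `COc1cc(/C=C/C(=O)/C=C/c2ccccc2)ccc1OCc1cn(CCCOc2cc(=O)oc3ccccc23)nn1` is not yet measured; it differs from compound 3 by hydrogen in place of methoxy on an aromatic carbon. This is the same kind of change as before, but the place differs: in compound 1 the methoxy is ortho to a large group, in compound 3 it is para to a large group. Because the earlier step was a number 8 percentage points lower from compound 1 to compound 2 (within the scatter), a similar small step is expected, a number 8 percentage points lower from compound 3 to compound 4 (within the scatter), giving for compound 4 an estimated 45%, within 25% to 60%.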

Compound 4, percent growth inhibition at one concentration: 43%
Estimate against measurement, compound 4: 2 percentage points above; the range from low to high includes it.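

Replacing methoxy with hydrogen in this assay gives a number 10 percentage points lower from compound 3 to compound 4 (within the scatter). Set beside the earlier case, the same replacement behaves alike on both cores: the same change on two cores in this assay, a number 8 percentage points lower (within the scatter) from compound 1 to compound 2 and a number 10 percentage points lower (within the scatter) from compound 3 to compound 4, 2 percentage points apart, within the scatter of two such steps

This agreement suggests that the small size of the step carries from one core to the other within these four compounds, but both steps lie within the scatter, so they do not show that removing the methoxy truly lowers growth inhibition, and two pairs cannot show that the result would hold on other cores.

On these data alone, it remains open what an amine or a carboxylic acid in place of the methoxy would do on either core. As far as these compounds go, it is also open whether either group would give a step beyond the scatter.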